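This account rests on a few compounds, and the source may have more. Where it says the series, first, only, none or still open, it means among the compounds named here.

Measured so far:
compound 1, `COc1cccc2cc(C(=O)NCC(=O)O)c(=O)oc12`, 15% in an assay on HeLa cells for displacement of a labelled ligand from adenosine receptor A3 (Homo sapiens), read by scintillation counting, with a stated time of 180 min, tested at 10 uM; a higher number here means more inhibition at the concentration tested (going by the name of the read-out), a lower number less inhibition
compound 2, `O=C(O)CNC(=O)c1cc2ccccc2oc1=O`, 0% in this assay

Compound 1 stands highest of the two numbers. Its nearest neighbour is compound 2, reached by a number 15 percentage points lower from compound 1 to compound 2 (beyond the scatter), a change of hydrogen in place of methoxy on an aromatic carbon.

Compound 3, `COc1cccc2cc(C(=O)NCCO)c(=O)oc12`, differs from compound 1 in another place: hydroxymethyl in place of carboxy on a saturated chain carbon bound to an amide-type nitrogen. Within the data shown here, the only measured step, that from compound 1 to compound 2, alters the methoxy group and leaves the carboxy untouched, so no measured step bears on the change from carboxy to hydroxymethyl. With nothing to lean on, the step in this assay is expected to be small, either direction, and quite possibly not beyond the scatter. Compound 3 is therefore estimated at 12%, within 0% to 30%, a step of a number 3 percentage points lower from compound 1 to compound 3 (within the scatter) that is expected rather than known.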

Compound 3, a percentage reported as inhibition, at one concentration (the size of the read-out at that concentration, not a potency): 1%
Compound 3: the middle estimate sits 11 percentage points above what was measured, within the range that was stated.
By their numbers in this assay, from the lowest: compounds 2 and 3 (each within the scatter of the next); then compound 1.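

Going by this assay, the change from carboxy to hydroxymethyl on a saturated chain carbon bound to an amide-type nitrogen gives a number 14 percentage points lower from compound 1 to compound 3 (beyond the scatter) and so shows that the read-out also responds to a change at this place on the chain. Together with the step to compound 2, this makes two single changes away from compound 1, one at the methoxy group and one at the carboxy, and each lowers the number beyond the scatter. No measurement at hand accounts for the step at the carboxy.

On these data alone, it remains open whether a methyl ester, a primary amide or an amine at this place on the chain would keep the number of compound 1, and whether a longer chain ending in the carboxylic acid would change it. As far as these compounds go, the effect of an ethoxy group or a chlorine atom in place of the methoxy group also remains open.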